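The compounds below may be only part of what the source reports. "The series", "measured", "known", "first", "only" and "open" are said of these compounds alone.

Measured so far in a functional assay on MDA-MB-231 cells (Homo sapiens) for inhibition, read by CellTiter-Glo, with a stated time of 72 h; on this read-out higher numbers stand for lower toxicity in this test and lower numbers for higher toxicity in this test
- compound 1 (`CC1=C(CC(=O)NCCN(C)C)c2cc(F)ccc2/C1=C\c1ccncc1`) gives 18100 nM
- compound 2 (`COC(=O)[C@@H](C)NC(=O)CC1=C(C)/C(=C/c2ccc(SC)cc2)c2ccc(F)cc21`) gives 32000 nM

Compound 2 at 32000 nM lies within the scatter of compound 1, so these two numbers set no order. Compared with compound 2, compound 3 (`COC(=O)[C@H](C)NC(=O)CC1=C(C)/C(=C/c2ccc(SC)cc2)c2ccc(F)cc21`) shows this difference: the two compounds have the same atoms and bonds and differ only in configuration as drawn: 1 of 2 stereo elements differ; a stereocentre at a saturated chain carbon is drawn R in compound 2 and S in compound 3 and nothing else. Among the measured compounds shown here, no measured pair isolates such a change, so the data give no size for it. No step beyond the scatter is expected in this assay in either direction. The estimated 1.1-fold lower number from compound 2 to compound 3 (0.03 log units; within the scatter) is expected to stay small. For compound 3 the expected value is 30000 nM with an estimated range of 14000 nM to 60000 nM in this read-out.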

Compound 3, half-maximal cytotoxic concentration: 38900 nM
Estimate against measurement, compound 3: 1.3-fold (0.11 log units) below; measured number inside the range.
By their numbers in this assay, from the lowest: compounds 1, 2 and 3 (each within the scatter of the next, the first and the last beyond it).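

In this assay, the stereocentre at the saturated chain carbon now has a measured size: a 1.2-fold higher number from compound 2 to compound 3 (0.08 log units; within the scatter), so drawing this centre R or S sets no order between these two compounds. Among the compounds shown here, this pair isolates that single stereocentre, which the earlier compounds could not do: the fact that compounds 2 and 3 differ only in the configuration as drawn.

Still open, as far as these compounds go, is whether the configuration stays without a measurable step when the methyl ester gives way to a carboxylic acid. The same question holds for a longer chain in place of the methyl group on the stereocentre.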